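The source may hold more compounds than are shown below. What is called first, only, known or untested is meant among the compounds shown, and "the series" means these compounds.

Compound 1 `Cc1cc(OCc2cccc(F)c2)ccc1CN[C@@H](C)C(N)=O` sits in the middle of the three numbers obtained so far. In an assay on Sf9 cells for inhibition of Amine oxidase [flavin-containing] B (Homo sapiens), with stated times of 15 min and 60 min (a higher number here means a weaker inhibitor, a lower number a stronger inhibitor), compound 1 gives 69 nM. Compound 2 `C[C@H](NCc1ccc(OCc2cccc(F)c2)cc1Cl)C(N)=O` gives 28 nM, and compound 3 `Cc1cc(OCc2cccc(F)c2)ccc1CN1CC[C@H]1C(N)=O` gives 258 nM. The change from compound 1 to compound 2 is a 2.5-fold lower number from compound 1 to compound 2 (0.39 log units; beyond the scatter), and the change from compound 1 to compound 3 is a 3.7-fold higher number from compound 1 to compound 3 (0.57 log units; beyond the scatter).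

Compound 4 `C#CCN(Cc1ccc(OCc2cccc(F)c2)cc1C)[C@@H](C)C(N)=O` differs from compound 1 by a single change: propargyl in place of hydrogen on an amine nitrogen. Neither measured step covers this change directly. The step from compound 1 to compound 2 alters an aromatic substituent and says nothing about the amine nitrogen. The step from compound 1 to compound 3 does alter the surroundings of that nitrogen, by tying it into a ring, and this weakened inhibition; an added propargyl leaves the chain open, so that step is only a loose guide. The expectation is therefore a small change in this assay, with direction uncertain and a wide range. For compound 4 the estimate in this assay is 40 nM, between 8 nM and 200 nM, which would mean a 1.7-fold lower number from compound 1 to compound 4 (0.24 log units; within the scatter).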

Compound 4, half-maximal inhibitory concentration: 320 nM
Estimate against measurement, compound 4: 8.0-fold (0.90 log units) below; the measured number lies above the stated range.
By their numbers in this assay, from the lowest: compound 2; then compound 1; then compounds 3 and 4 (each within the scatter of the next).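

In this assay, the amine nitrogen of compound 1 does not accept propargyl in place of hydrogen without a cost, as shown by a 4.6-fold higher number from compound 1 to compound 4 (0.67 log units; beyond the scatter). The earlier step, a 3.7-fold higher number from compound 1 to compound 3 (0.57 log units; beyond the scatter), also replaced the hydrogen on this nitrogen, but by closing a ring; the new result shows that the number also rises when the chain stays open, so both changes shown at this nitrogen weaken inhibition. Nothing available explains the rise.

Still open, as far as these compounds go, is whether the triple bond matters or whether replacing the hydrogen is enough, which a methyl or propyl group on the same nitrogen would help to separate. It is also unknown whether propargyl would cost as much with chloro in place of methyl on the aromatic carbon.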